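Triazolyl substituents on the adenosine-derived series

The source may hold more compounds than are shown below. What is called first, only, known or untested is meant among the compounds shown, and "the series" means these compounds.

Measured compounds:
compound 1 `CNc1nc(-n2cc(-c3ccccn3)nn2)nc2c1ncn2[C@@H]1O[C@H](CO)[C@@H](O)[C@H]1O`: 1970 nM
compound 2 `CCNC(=O)[C@H]1O[C@@H](n2cnc3c(NC)nc(-n4cc(Cc5ccccc5)nn4)nc32)[C@H](O)[C@@H]1O`: 510 nM
compound 3 `CCCCc1cn(-c2nc(NC)c3ncn([C@@H]4O[C@H](C(=O)NCC)[C@@H](O)[C@H]4O)c3n2)nn1`: 750 nM

In an assay on CHO cells for displacement of a labelled ligand from adenosine receptor A1 (Homo sapiens) (on this read-out lower numbers stand for stronger inhibition and higher numbers for weaker inhibition), compound 1 gives the highest of the three numbers; compound 3 lies nearer to it and compound 2 furthest, both beyond the scatter. Compound 4 `CNc1nc(-n2cc(CC3CCCCC3)nn2)nc2c1ncn2[C@@H]1O[C@H](CO)[C@@H](O)[C@H]1O` has not yet been measured; relative to compound 1 the change is cyclohexylmethyl in place of pyridin-2-yl on an aromatic carbon. Among the compounds with values here, the only measured step that bears on it is the swap of an aromatic ring for a saturated chain on the triazole of compound 2, a 1.5-fold higher number from compound 2 to compound 3 (0.17 log units; within the scatter), which left this assay essentially unchanged. On that basis compound 4 is expected to show a small step, a 1.5-fold lower number from compound 1 to compound 4 (0.18 log units; within the scatter), if any, rather than a large one. The estimate for compound 4 is 1300 nM, with a range from 450 nM to 3800 nM.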

Compound 4, inhibition constant: 1430 nM
Estimate against measurement, compound 4: 1.1-fold (0.04 log units) below; measured number inside the range.
By their numbers in this assay, from the lowest: compounds 2, 3, 4 and 1 (each within the scatter of the next, the first and the last beyond it).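

In this assay the exchange of pyridin-2-yl for cyclohexylmethyl gives a 1.4-fold lower number from compound 1 to compound 4 (0.14 log units; within the scatter) and so leaves the number unmoved beyond the scatter. On this aromatic carbon, then, an aromatic ring with a hetero atom and its hydrogen-bond acceptor can give way to a carbon-only non-aromatic ring on the core of compound 1 without a readable step. No measurement available here explains this result. Still open, going by these compounds, is whether an amine or a carboxylic acid on this carbon would give a step beyond the scatter. Also open, on these data alone, is whether pyridin-2-yl and cyclohexylmethyl would match on the core of compound 2.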